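Replacing 4-cyanophenyl with 3-nitrophenyl on the shared core

The compounds below may be only part of what the source reports. "The series", "measured", "known", "first", "only" and "open" are said of these compounds alone.

In a functional assay on HepG2 cells (Homo sapiens) for antiproliferative activity, read by MTT assay, with a stated time of 72 h (on this read-out lower numbers stand for stronger inhibition and higher numbers for weaker inhibition), compound 1 `O=C(N/N=C/c1ccc(F)cc1)Nc1ccc(Oc2ccnc3[nH]ccc23)c(F)c1` gives 3880 nM and compound 2 `N#Cc1ccc(/C=N/NC(=O)Nc2ccc(Oc3ccnc4[nH]ccc34)c(F)c2)cc1` gives 850 nM as the lower of the two numbers. The change leading to compound 3 `O=C(N/N=C/c1cccc([N+](=O)[O-])c1)Nc1ccc(Oc2ccnc3[nH]ccc23)c(F)c1` is 3-nitrophenyl in place of 4-cyanophenyl on a carbon with a double bond to nitrogen with 3-nitrophenyl in place of 4-cyanophenyl on a carbon with a double bond to nitrogen. Going by the values given here, the one measured step, a 4.6-fold lower number from compound 1 to compound 2 (0.66 log units; beyond the scatter) for cyano in place of fluoro on an aromatic carbon, is modest and beyond the scatter, and no measured compound carries 3-nitrophenyl. A modest step of similar size towards weaker inhibition in this assay is therefore expected, and a 2.4-fold higher number from compound 2 to compound 3 (0.37 log units; beyond the scatter) is the estimated step in that direction. For compound 3 the expected value is 2000 nM with an estimated range from 650 nM to 6000 nM as its likely span.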

Compound 3, half-maximal inhibitory concentration: 5180 nM
Compound 3: the middle estimate sits 2.6-fold (0.41 log units) below what was measured; low and high end bracket the measured number.
By their numbers in this assay, from the lowest: compound 2; then compounds 1 and 3 (each within the scatter of the next).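

In this assay the group on a carbon with a double bond to nitrogen is changed a second time, and 3-nitrophenyl gives a 6.1-fold higher number from compound 2 to compound 3 (0.78 log units; beyond the scatter), so the lower number of compound 2 does not carry over to this group. Set against 4-fluorophenyl, the same group gives a 1.3-fold higher number from compound 1 to compound 3 (0.13 log units; within the scatter), which leaves 4-cyanophenyl as the only one of the three groups that stands apart. Nothing available bears on why these numbers differ.

Compound 3 changes both the group and its place on the ring at once, so the two cannot be told apart. From the compounds shown here alone, whether 4-nitrophenyl or 4-aminophenyl would stay near compound 2 remains open.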